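The source may hold more compounds than are shown below. What is called first, only, known or untested is meant among the compounds shown, and "the series" means these compounds.

Measured in an assay for binding affinity to Corticotropin releasing factor receptor (Rattus norvegicus); on this read-out lower numbers stand for stronger inhibition and higher numbers for weaker inhibition:
- compound 1 `CCCC(C)n1c(CC)nc2c(-c3ccc(OC(F)F)cc3C)nccc21` gives 9 nM
- compound 2 `CCCC(C)n1c(CC)nc2c(-c3ccc(OC(F)(F)F)cc3Cl)nccc21` gives 2.8 nM
- compound 3 `CCc1nc2c(-c3ccc(Cl)cc3C(F)(F)F)nccc2n1C(CC)C1CC1` gives 4.4 nM

Compound 1 stands at the highest of the three numbers in this assay; compound 3 sits lower by a step beyond the scatter, and compound 2 lower still, also beyond the scatter.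

Compound 4 `CCCC(C)n1c(CC)nc2c(-c3ccc(Cl)cc3C)nccc21` has not been measured in this assay. It differs from compound 1 in one place: chloro in place of difluoromethoxy on an aromatic carbon.

For the measured compounds named here, no measured pair isolates this change. Compound 3 carries chloro on the same ring and gives the lower 4.4 nM, but it differs from compound 1 elsewhere too. A small step downward from compound 1 to compound 4 is expected, possibly within the scatter, a 1.6-fold lower number from compound 1 to compound 4 (0.21 log units; within the scatter). For compound 4 the estimate is 5.5 nM, range 2.2 nM to 14 nM.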

Compound 4, inhibition constant: 9.1 nM
Compound 4: middle estimate off by 1.7-fold (0.22 log units), on the low side; measured number inside the range.
By their numbers in this assay, from the lowest: compounds 2 and 3 (each within the scatter of the next); then compounds 1 and 4 (each within the scatter of the next).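

In this assay, chloro in place of difluoromethoxy on this aromatic carbon, para to a large group, gives a 1.0-fold higher number from compound 1 to compound 4 (0.00 log units; within the scatter). In this pair, the single chlorine serves as well as the larger difluoromethoxy group, and the hydrogen-bond acceptor counted on difluoromethoxy is not needed to hold the read-out. No evidence is available to explain this equivalence. Still open, as far as these compounds go, is whether an amine, a carboxylic acid or a longer alkoxy chain on this carbon would hold the read-out as well.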